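The source may report more compounds than this note shows. Statements on the series, on what has been measured and on what is new or still open speak of the compounds shown alone.

Measured so far in a functional assay on SK-BR-3 cells (Homo sapiens) for antiproliferative activity, read by MTT assay, with a stated time of 72 h; a higher number here means a weaker inhibitor, a lower number a stronger inhibitor:
Compound 1 `Cc1cc(N(C)C)nc2ccc(NC(=O)c3ccc(Cl)c(Cl)c3)cc12`: compound 1 reaches only the assay limit > 50000 nM.
Compound 2 `CCN1CCN(c2cc(C)c3cc(NC(=O)c4ccc5ccccc5n4)ccc3n2)CC1`: compound 2 gives 3760 nM.
Compound 3 `CNc1cc(C)c2cc(NC(=O)c3ccc(Cl)c(Cl)c3)ccc2n1`: compound 3 gives 6350 nM.

Of the two plain numbers, compound 2 has the lower one, yet the value of compound 3 sits within the usual scatter of it, so the two cannot be told apart. For the measured compounds named here, the only measured step, an at least 7.8-fold lower number from compound 1 to compound 3 (0.89 log units; beyond the scatter), concerns the nitrogen on the ring, not the amide, so no measured step bears on the change now in question. Compound 4 `CCN1CCN(c2cc(C)c3cc(NC(=O)c4cccc(C)c4)ccc3n2)CC1` differs from compound 2 by 3-methylphenyl in place of quinolin-2-yl on a carbonyl carbon. With nothing comparable among the measured compounds, the direction is uncertain; the expectation is a modest rise, a 2.1-fold higher number from compound 2 to compound 4 (0.33 log units; beyond the scatter). Compound 4 is therefore estimated at 8000 nM, with a range from 2500 nM to 30000 nM.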

Compound 4, half-maximal inhibitory concentration: 13700 nM
The estimate for compound 4 lay 1.7-fold (0.23 log units) below the measured number; measured number inside the range.
By their numbers in this assay, from the lowest: compounds 2 and 3 (each within the scatter of the next); then compound 4. At a limit, above all of these: compound 1.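

In this assay, for the compounds shown here, replacing quinolin-2-yl with 3-methylphenyl on a carbonyl carbon gives a 3.6-fold higher number from compound 2 to compound 4 (0.56 log units; beyond the scatter), the first measured change at this position. With the rest of the molecule unchanged, the group on the carbonyl carbon alters the number, and here quinolin-2-yl gives the lower one. No measurement shown accounts for the size of this step.

Going by these compounds, it remains open whether the ring nitrogen or the second ring of quinolin-2-yl carries the difference. A pyridin-2-yl group on the same carbonyl carbon would help separate the two.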